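This account rests on a few compounds, and the source may have more. Where it says the series, first, only, none or still open, it means among the compounds named here.

Measured in a functional assay on SMMC-7721 cells (Homo sapiens) for cytotoxicity, read by MTT assay, with a stated time of 24 h; on this read-out higher numbers stand for weaker inhibition and lower numbers for stronger inhibition:
- compound 1 (`O=C1/C(=C/c2ccccc2F)CN(S(=O)(=O)c2ccc(F)cc2)C/C1=C\c1ccccc1F`): 8370 nM
- compound 2 (`O=C1/C(=C/c2cccc([N+](=O)[O-])c2)CN(S(=O)(=O)c2ccc(F)cc2)C/C1=C\c1cccc([N+](=O)[O-])c1`): 3980 nM
- compound 3 (`CC(=O)Nc1ccc(S(=O)(=O)N2C/C(=C\c3cccc([N+](=O)[O-])c3)C(=O)/C(=C/c3cccc([N+](=O)[O-])c3)C2)cc1`): 8420 nM

Compound 2 has the lowest number of the three. Compound 4 (`O=C1/C(=C/c2cccc([N+](=O)[O-])c2)CN(S(=O)(=O)c2ccc(F)cc2)C/C1=C\c1ccccc1F`) differs from it as follows: 2-fluorophenyl in place of 3-nitrophenyl on a double-bonded chain carbon bound to a double-bonded ring carbon. For the measured compounds named here, the one measured single-place step, a 2.1-fold higher number from compound 2 to compound 3 (0.33 log units; beyond the scatter), lies elsewhere on the molecule and informs only the likely size of a step. Compound 1 bears more directly, since it carries 2-fluorophenyl in place of both 3-nitrophenyl groups and gives 8370 nM. A small move toward a higher number in this assay is therefore expected, landing between the values of compound 2 and compound 1. The expected step is a 1.5-fold higher number from compound 2 to compound 4 (0.16 log units; within the scatter). For compound 4 the estimate is 5800 nM, with an expected range of 3000 nM to 11000 nM.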

Compound 4, half-maximal inhibitory concentration: 7820 nM
Compound 4: middle estimate off by 1.3-fold (0.13 log units), on the low side; the measured number falls inside the stated range.
By their numbers in this assay, from the lowest: compounds 2, 4, 1 and 3 (each within the scatter of the next, the first and the last beyond it).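

Compound 4 separates the two arms of the shared core, which compound 1 and compound 2 could only show changed together. In this assay, 2-fluorophenyl in place of 3-nitrophenyl gives a 2.0-fold higher number from compound 2 to compound 4 (0.29 log units; within the scatter), and the reverse exchange on the other arm gives a 1.1-fold lower number from compound 1 to compound 4 (0.03 log units; within the scatter), so neither single exchange at this position stands clear of the scatter. No measurement here offers a cause for these steps.

Open, from the compounds shown here alone, is how an amine or a carboxylic acid would read on this double-bonded chain carbon in this assay.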